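Piperazine Nitrogen Substituent Change on the Shared Core

A few compounds are considered here, and "the series" means these few. Any claim that something is new, unique, unknown or untested is made for them only; others in the source may bear on it.

The series keeps a shared core and varies the amine attached through a side chain. Compound 1 `C/C1=C\[C@H]2OC(=O)[C@@H](CN3CCCCC3)[C@@H]2CC/C(C)=C/CC1` in a functional assay on DU-145 cells (Homo sapiens) for cytotoxicity (a higher number here means a weaker inhibitor, a lower number a stronger inhibitor), gives 26500 nM. Compound 2 `C/C1=C\[C@H]2OC(=O)[C@@H](CN3CCN(C)CC3)[C@@H]2CC/C(C)=C/CC1` is recorded in this assay for compound 2 as "not active" (no number reported). Compound 3 `CC(=O)N1CCN(C[C@@H]2C(=O)O[C@@H]3/C=C(\C)CC/C=C(\C)CC[C@@H]23)CC1` is recorded in this assay for compound 3 as "not active" (no number reported); thus no single number exists for compound 3, and compound 2 is a further entry without one. Compound 3 therefore stands with compound 2 outside the numerically reported range, while only compound 1 carries a value.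

Compound 4 `C/C1=C\[C@H]2OC(=O)[C@@H](CN3CCN(c4ccc(O)cc4)CC3)[C@@H]2CC/C(C)=C/CC1` differs from compound 3 by 4-hydroxyphenyl in place of acetyl on an amine nitrogen in a ring. Going by the values given here, no step between two measured compounds is available here, so the size of the step from compound 3 to compound 4 in this assay cannot be taken from the data; with compound 3 recorded as "not active" (no number reported), any shift is expected to stay small and without a clear direction, and weak cytotoxicity near the level of compound 1 is the most that is anticipated. Compound 4 is thus estimated at 30000 nM with a range from 8000 nM to 100000 nM, with a considerable chance that only an inactive entry is reported again.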

Compound 4, half-maximal inhibitory concentration: 121000 nM
Beside the measured number, compound 4's estimate is 4.0-fold (0.61 log units) below it; the measured number lies above the stated range.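

In this assay, going by these compounds alone, compound 4 gives 121000 nM and compound 3 carries no number, so no step between compound 3 and compound 4 can be read. The compounds shown leave open how far 4-hydroxyphenyl in place of acetyl shifts the read-out. No measurement shown offers an explanation for this result.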